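Adding a hydroxy group to the phenyl of compound 1

This account rests on a few compounds, and the source may have more. Where it says the series, first, only, none or still open, it means among the compounds named here.

Compound 1 `O=C(Cc1csc2nc(-c3ccc(Br)cc3)cn12)N/N=C/c1ccccc1`: 52500 nM
Compound 2 `O=C(Cc1csc2nc(-c3ccc(Br)cc3)cn12)N/N=C/c1ccccc1O`: 19100 nM

In a functional assay on EKVX cells (Homo sapiens) for inhibition, read by sulforhodamine B assay, with a stated time of 48 h (a lower number here means a stronger inhibitor of growth, a higher number a weaker inhibitor of growth), compound 1 gives 52500 nM, the higher of the two numbers, which makes it the weaker growth inhibitor of the pair. The next case is compound 3 `O=C(Cc1csc2nc(-c3ccc(Br)cc3)cn12)N/N=C/c1ccc(O)cc1`, where phenyl goes to 4-hydroxyphenyl: hydroxy in place of hydrogen on an aromatic carbon, para to a large group (hydroxy in place of hydrogen on an aromatic carbon). Within the data shown here, only one measured step is of the same kind: a 2.7-fold lower number from compound 1 to compound 2 (0.44 log units; beyond the scatter). It is modest, and its hydroxy stands on a different carbon of that ring, so it is an uncertain guide. A similar modest step to a lower number is therefore expected in this assay. For compound 3 the estimated value is 27000 nM, with an expected range of 11000 nM to 60000 nM. The estimate amounts to an expected 1.9-fold lower number from compound 1 to compound 3 (0.29 log units; within the scatter).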

Compound 3, concentration for total growth inhibition: 66100 nM
Compound 3: middle estimate off by 2.4-fold (0.39 log units), on the low side, outside the stated range (above it).
By their numbers in this assay, from the lowest: compound 2; then compounds 1 and 3 (each within the scatter of the next).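

In this assay the 4-hydroxyphenyl change gives a 1.3-fold higher number from compound 1 to compound 3 (0.10 log units; within the scatter) and so does not separate compound 3 from compound 1, unlike the hydroxy group of compound 2 on its different ring carbon. Between the two hydroxy isomers, 4-hydroxyphenyl in place of 2-hydroxyphenyl gives a 3.5-fold higher number from compound 2 to compound 3 (0.54 log units; beyond the scatter) and thus shows that the ring place of the hydroxy group matters for this pair, with the gain over compound 1 seen only in compound 2. No measurement available here accounts for this difference between the two placements.

From the compounds shown here alone, whether the hydroxy group itself is needed at the place it holds in compound 2 stays open, and a methoxy group or an amine there would bear on that. Also open, going by these compounds, is whether the gap between the two isomers persists with a chloro group in place of the bromo group on the shared core.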